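The source may report more compounds than this note shows. Statements on the series, on what has been measured and on what is new or still open speak of the compounds shown alone.

Within the data shown here, compound 3 `CCn1c(C(=O)NCC(OC)OC)ccc1C(CC)(CC)c1ccc(OCC(O)C(C)(C)C)c(C)c1` gives in an ADME assay on L02 cells (Homo sapiens) for cytotoxicity, read by MTT assay, with a stated time of 48 h (on this read-out higher numbers stand for weaker inhibition and lower numbers for stronger inhibition), a value of 22200 nM, the highest of the three numbers measured so far. Compound 1 `CCn1c(C(=O)NCCN(C)C)ccc1C(CC)(CC)c1ccc(OCC(O)C(C)(C)C)c(C)c1` gives 2600 nM and compound 2 `CCN(CC)CCCNC(=O)c1ccc(C(CC)(CC)c2ccc(OCC(O)C(C)(C)C)c(C)c2)n1CC` gives 2500 nM; the step of a 1.0-fold lower number from compound 1 to compound 2 (0.02 log units; within the scatter) shows that the two differ little, whereas an 8.5-fold higher number from compound 1 to compound 3 (0.93 log units; beyond the scatter) and an 8.9-fold higher number from compound 2 to compound 3 (0.95 log units; beyond the scatter) both place compound 3 well apart from them. The step from compound 3 to compound 4 `C=CCN(C)C(=O)c1ccc(C(CC)(CC)c2ccc(OCC(O)C(C)(C)C)c(C)c2)n1CC` makes the change (allyl(methyl)amino in place of (2,2-dimethoxyethyl)amino on a carbonyl carbon). The measured steps leading to compound 3 both replaced a chain bearing a dimethylamino or diethylamino group with dimethoxymethyl, and each moved the number up by a modest amount. Compound 4 carries neither such amino chain nor the dimethoxymethyl group, so those steps give only indirect guidance; with no amino chain returning, no large fall back toward compound 1 or compound 2 is expected, and the step of a 1.5-fold lower number from compound 3 to compound 4 (0.17 log units; within the scatter) is expected to stay near the scatter. Compound 4 is therefore estimated at 15000 nM, with a range from 5000 nM to 40000 nM.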

Compound 4, half-maximal inhibitory concentration: 6300 nM
Compound 4: middle estimate off by 2.4-fold (0.38 log units), on the high side; the range from low to high includes it.
By their numbers in this assay, from the lowest: compounds 2 and 1 (each within the scatter of the next); then compound 4; then compound 3.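

In this assay, the step with allyl(methyl)amino on the carbonyl carbon is a 3.5-fold lower number from compound 3 to compound 4 (0.55 log units; beyond the scatter), so a group without the dimethylamino or diethylamino chain end of compound 1 and compound 2 need not stay at the level of compound 3. That chain end still marks a difference, with a 2.5-fold higher number from compound 2 to compound 4 (0.40 log units; beyond the scatter) and a 2.4-fold higher number from compound 1 to compound 4 (0.38 log units; beyond the scatter), which places compound 4 on a level of its own between the others. Nothing measured here explains these differences.

The step from compound 3 changes the amide hydrogen and the two methoxy groups together, so the compounds shown do not separate the two changes. As far as these compounds go, it also remains open how a ring amine such as piperidine or morpholine, or a chain ending in a carboxylic acid, would read at this carbonyl carbon.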